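Thiophene Swap Repeated on a Second Fused Core

This account rests on a few compounds, and the source may have more. Where it says the series, first, only, none or still open, it means among the compounds named here.

Compound 1 `Cc1cc(-c2nc3sc(C)cn3c2/C=N/NC(=N)N)c(C)s1` and compound 2 `Cc1cn2c(/C=N/NC(=N)N)c(-c3cccs3)nc2s1` share one core. In a functional assay on cells (Cancer cell lines, Homo sapiens) for inhibition (on this read-out lower numbers stand for stronger inhibition of growth and higher numbers for weaker inhibition of growth), compound 1 gives 12000 nM and compound 2 gives 6460 nM; the change thiophen-2-yl in place of 2,5-dimethylthiophen-3-yl on an aromatic carbon produced a 1.9-fold lower number from compound 1 to compound 2 (0.27 log units; within the scatter). Compound 3 `Cc1cc(-c2nc3n(c2/C=N/NC(=N)N)CCS3)c(C)s1` carries a different core, and the difference between the two cores is not broken down here. In this assay compound 3 gives 24000 nM. Compound 4 `N=C(N)N/N=C/c1c(-c2cccs2)nc2n1CCS2` has not been measured; it differs from compound 3 by thiophen-2-yl in place of 2,5-dimethylthiophen-3-yl on an aromatic carbon, the same kind of change, though here the place is also two ring bonds from two ring atoms that each bear a fused ring. On the strength of a 1.9-fold lower number from compound 1 to compound 2 (0.27 log units; within the scatter), the same kind of change is expected to give a 1.9-fold lower number from compound 3 to compound 4 (0.28 log units; within the scatter). For compound 4 the estimate in this assay is 12500 nM, between 5000 nM and 30000 nM.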

Compound 4, concentration for 50% growth inhibition: 39800 nM
Compound 4: middle estimate off by 3.2-fold (0.50 log units), on the low side, outside the stated range (above it).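

In this assay, putting thiophen-2-yl in place of 2,5-dimethylthiophen-3-yl on the second core gave a 1.7-fold higher number from compound 3 to compound 4 (0.22 log units; within the scatter). Set beside the earlier step, the result does not match: the same change on two cores in this assay, a 1.9-fold lower number (0.27 log units; within the scatter) from compound 1 to compound 2 and a 1.7-fold higher number (0.22 log units; within the scatter) from compound 3 to compound 4, 3.1-fold (0.49 log units) apart, beyond the scatter of two such steps. So the step seen on the core of compound 1 did not carry over as a number to the core of compound 3, although each step alone lies within the scatter, and two pairs cannot show why the cores part or whether the gap would recur with other groups. The compounds shown leave open how either core responds on that aromatic carbon to a group other than these two thiophenes, such as a phenyl ring or an amine.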